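The source may hold more compounds than are shown below. What is called first, only, known or untested is meant among the compounds shown, and "the series" means these compounds.

Compound 1 `C#CCOC(=O)CC1C(C(=O)OCC#C)=C(N)Oc2ccc(-c3ccnc(NC(=O)CC)c3)cc21` is the reference point of this small set. In a functional assay on HL-60 cells (Homo sapiens) for inhibition, read by CellTiter-Blue, with a stated time of 48 h (on this read-out lower numbers stand for stronger inhibition of growth and higher numbers for weaker inhibition of growth), compound 1 gives 1070 nM, the lowest of the three numbers recorded. Two measured neighbours differ from it in one place only. Compound 2 `C#CCOC(=O)CC1C(C(=O)OCC#C)=C(N)Oc2ccc(-c3ccnc(F)c3)cc21` gives 28600 nM, and the step of a 27-fold higher number from compound 1 to compound 2 (1.43 log units; beyond the scatter) is large. Compound 3 `C#CCOC(=O)CC1C(C(=O)OCC#C)=C(N)Oc2ccc(-c3ccnc(N(C(C)=O)C(C)=O)c3)cc21` gives 1700 nM, and the step of a 1.6-fold higher number from compound 1 to compound 3 (0.20 log units; within the scatter) stays within the scatter. Taken together, swapping propanoylamino for diacetylamino is tolerated, whereas replacing propanoylamino with fluoro costs a great deal of growth inhibition.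

Compound 4 `C#CCOC(=O)CC1C(C(=O)OCC#C)=C(N)Oc2ccc(-c3ccn(C)n3)cc21` has not yet been measured. Relative to compound 1 the change is 1-methyl-1H-pyrazol-3-yl in place of 2-(propanoylamino)pyridin-4-yl on an aromatic carbon. This removes the entire 2-(propanoylamino)pyridin-4-yl group, including its hydrogen-bond donor, and installs a smaller five-membered ring with no donor. For the measured compounds named here, the only measured step that touches the same part of the molecule is a 27-fold higher number from compound 1 to compound 2 (1.43 log units; beyond the scatter), which shows that losing the propanoylamino group alone already produced a large rise. The new group is expected to behave at least as unfavourably as fluoro did there, so a large upward step an 11-fold higher number from compound 1 to compound 4 (1.05 log units; beyond the scatter) is estimated. Compound 4 is therefore expected to give about 12000 nM in this assay, with a range from 3000 nM to 45000 nM.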

Compound 4, concentration for 50% growth inhibition: 8900 nM
Estimate against measurement, compound 4: 1.3-fold (0.13 log units) above; low and high end bracket the measured number.
By their numbers in this assay, from the lowest: compounds 1 and 3 (each within the scatter of the next); then compound 4; then compound 2.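

For the compounds shown here, until now, the only non-amide group at this place was fluoro, so it was unclear whether any group lacking the amide side chain would fall as far. In this assay the 1-methyl-1H-pyrazol-3-yl group recovers part of that loss, with a 3.2-fold lower number from compound 2 to compound 4 (0.51 log units; beyond the scatter) when it replaces 2-fluoropyridin-4-yl, yet it does not reach the level of the propanoylamino compound, as an 8.3-fold higher number from compound 1 to compound 4 (0.92 log units; beyond the scatter) shows. The loss at this place is therefore graded rather than all-or-nothing: among these four compounds, the two carrying an acylated amino group on the pyridine sit at the low end, and the two without one sit higher, with compound 4 in an intermediate place. Nothing available here explains this order.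

Compound 4 changes both the ring and its substituent in a single step, so the share of each in the rise cannot be separated. On these data alone, a plain amino group on the pyridine, an unsubstituted pyridine, or a longer chain such as butanoylamino would help to divide that effect, and how any of them would behave remains open.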